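Trimming the acyl group of compound 1

This account rests on a few compounds, and the source may have more. Where it says the series, first, only, none or still open, it means among the compounds named here.

Compound 1 `O=C(CN(Cc1ccc(C(=O)NO)cc1)C(=O)c1cccc2ccccc12)NCc1ccccc1` stands as the stronger of the two measured compounds in an assay on Sf9 cells for inhibition of protein deacetylase HDAC6 (Homo sapiens), read by fluorescence, with a stated time of 90 min; on this read-out higher numbers stand for weaker inhibition and lower numbers for stronger inhibition: compound 1 gives 10 nM. Compound 2 `CN(C)c1ccc(C(=O)N(Cc2ccc(C(=O)NO)cc2)C(C)(C)C(=O)NCc2ccccc2)cc1`, built on the same hydroxamic acid but with a different acyl group and a different linker, gives 70 nM, a weaker result that lies beyond the usual scatter. Compound 3 `Cc1ccc(C(=O)N(CC(=O)NCc2ccccc2)Cc2ccc(C(=O)NO)cc2)c(C)c1` has not yet been measured. It differs from compound 1 in one place: 2,4-dimethylphenyl in place of naphthalen-1-yl on a carbonyl carbon. Among the measured compounds shown here, no measured pair shows this change on its own, so its effect is open. For the measured compounds named here, the only hint is that compound 1 gives 10 nM while compound 2, with another acyl group, gives 70 nM. The step of a 2.5-fold higher number from compound 1 to compound 3 (0.40 log units; beyond the scatter) is therefore expected to be modest, toward weaker inhibition, near the edge of the scatter. Compound 3 is expected to give about 25 nM, within 8 nM to 80 nM.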

Compound 3, half-maximal inhibitory concentration: 60 nM
Compound 3: the middle estimate sits 2.4-fold (0.38 log units) below what was measured; the range from low to high includes it.
By their numbers in this assay, from the lowest: compound 1; then compounds 3 and 2 (each within the scatter of the next).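

In this assay, the group on the carbonyl carbon bonded to the amide-type nitrogen proves to matter on its own: placing 2,4-dimethylphenyl where naphthalen-1-yl stood is a 6.0-fold higher number from compound 1 to compound 3 (0.78 log units; beyond the scatter) and gives weaker inhibition. Among the compounds shown here, this is the first comparison here that changes one place only, with the rest of compound 1 held fixed. It shows that one six-membered aromatic ring carrying two methyl groups does not match the two rings of naphthalen-1-yl at this position, and the data on hand offer no explanation for the difference.

Whether the second ring or the methyl groups account for the step remains open, and unsubstituted phenyl or naphthalen-2-yl on the same carbonyl carbon would help separate the two. Going by these compounds, how the shared core responds to changes elsewhere, such as a longer chain in place of the benzyl group on the amide, also remains open.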